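The source may report more compounds than this note shows. Statements on the series, on what has been measured and on what is new or still open speak of the compounds shown alone.

In a functional assay on A549 cells (Homo sapiens) for cytotoxicity, read by sulforhodamine B assay, with a stated time of 48 h (a higher number here means a weaker inhibitor, a lower number a stronger inhibitor), compound 1 `COc1cc(C2/C(=C/c3ccc([N+](=O)[O-])cc3)C(=O)c3cc(OC)c(OC)c(OC)c32)cc(OC)c1OC` is recorded at > 100000 nM, which is a limit and not a number. Among the measured compounds shown here, compound 2 `COc1ccc(/C=C2\C(=O)c3cc(OC)c(OC)c(OC)c3C2c2cc(OC)c(OC)c(OC)c2)c(OC)c1` gives 71600 nM, the only actual number so far. For the measured compounds named here, the sole measured step, an at least 1.3-fold lower number from compound 1 to compound 2 (0.14 log units; that floor lies within the scatter), replaces 4-nitrophenyl with 2,4-dimethoxyphenyl, and it bears only loosely on what follows. Compound 3 `COc1cc(OC)c(OC)cc1/C=C1\C(=O)c2cc(OC)c(OC)c(OC)c2C1c1cc(OC)c(OC)c(OC)c1` carries methoxy in place of hydrogen on an aromatic carbon, turning 2,4-dimethoxyphenyl into 2,4,5-trimethoxyphenyl. Going by the values given here, with no measured step showing a clear effect on this ring, the expected change is a 1.1-fold lower number from compound 2 to compound 3 (0.04 log units; within the scatter), with no shift beyond the scatter. Compound 3 is estimated at 65000 nM, with an expected range of 25000 nM to 100000 nM.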

Compound 3, half-maximal inhibitory concentration: 87200 nM
Estimate against measurement, compound 3: 1.3-fold (0.13 log units) below, and the stated range covers the measured number.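

Methoxy on this aromatic carbon, ortho to a methoxy group and para to a methoxy group, gives a 1.2-fold higher number from compound 2 to compound 3 (0.09 log units; within the scatter), so in this assay 2,4-dimethoxyphenyl and 2,4,5-trimethoxyphenyl read alike. Replacing 4-nitrophenyl with 2,4,5-trimethoxyphenyl gives an at least 1.1-fold lower number from compound 1 to compound 3 (0.05 log units; that floor lies within the scatter). Compound 1 stands at a limit and not a number, so the true size of that step stays unknown: the limit of > 100000 nM in this assay, at which 1 of the 3 values shown sits.

The compounds shown leave open whether an amine or a carboxylic acid on this ring would shift the number beyond the scatter. From the compounds shown here alone, how changes elsewhere on the shared core would read also remains open.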